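This account rests on a few compounds, and the source may have more. Where it says the series, first, only, none or still open, it means among the compounds named here.

Compound 2 `O=Cc1ccc(-c2cn3ccnc3c(-c3ccc4ncn(C5CCCCC5)c4c3)n2)cc1` stands lower than compound 1 `c1ccc(-c2cn3ccnc3c(-c3ccc4ncn(C5CCCCC5)c4c3)n2)cc1` in a functional assay on OVCAR-4 cells (Homo sapiens) for inhibition, read by sulforhodamine B assay, with a stated time of 48 h, tested at 10 uM (on this read-out higher numbers stand for more inhibition at the one concentration tested (going by the name of the read-out) and lower numbers for less inhibition), where compound 1 gives 34.5% and compound 2 gives 16.9%. Within the data shown here, the only measured step is a number 17.6 percentage points lower from compound 1 to compound 2 (beyond the scatter). Compound 3 `Clc1ccc(-c2cn3ccnc3c(-c3ccc4ncn(C5CCCCC5)c4c3)n2)cc1` differs from compound 2 by chloro in place of formyl on an aromatic carbon. Among the measured compounds shown here, no measured step exchanges formyl for chloro, so the expectation rests on one step alone. Because the step of a number 17.6 percentage points lower from compound 1 to compound 2 (beyond the scatter) came with the formyl's arrival, its departure is expected to bring part of that back, a step of a number 13.1 percentage points higher from compound 2 to compound 3 (beyond the scatter). Compound 3 is therefore estimated at 30%, between 10% and 50%.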

Compound 3, a percentage reported as inhibition, at one concentration (the size of the read-out at that concentration, not a potency): 4.57%
For compound 3 the middle estimate is 25.4 percentage points above the measured one; measured number outside the range, below it.
By their numbers in this assay, from the lowest: compound 3; then compound 2; then compound 1.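

Replacing formyl with chloro at this position, para to a large group, gives a number 12.3 percentage points lower from compound 2 to compound 3 (beyond the scatter) in this assay, so removing the formyl does not restore the higher number. Chloro in place of hydrogen gives a number 29.9 percentage points lower from compound 1 to compound 3 (beyond the scatter), so both substituents shown here stand below hydrogen, and chloro stands lowest of the three. Nothing available explains why either group lowers the number. Going by these compounds, whether an amine, a carboxylic acid or a methoxy group at this position would stand above or below hydrogen remains open.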